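A few compounds are considered here, and "the series" means these few. Any claim that something is new, unique, unknown or untested is made for them only; others in the source may bear on it.

Three compounds were measured:
compound 1, `O=C(O)CN1C(=O)/C(=C/c2nc3ccccc3n2Cc2ccccc2F)SC1=S`, 1860 nM;
compound 2, `O=C(O)CN1C(=O)/C(=C/c2nc3ccccc3n2Cc2ccc(F)cc2F)SC1=S`, 21700 nM;
compound 3, `O=C(O)CN1C(=O)/C(=C/c2nc3ccccc3n2Cc2cccc(F)c2)SC1=S`, 35700 nM.

These values come from a functional assay on PC-3 cells (Homo sapiens) for cytotoxicity, read by MTT assay, with a stated time of 48 h; a higher number here means a weaker inhibitor, a lower number a stronger inhibitor. All three share one core and differ only in the group carried on the saturated chain carbon bound to an aromatic nitrogen. Between compound 1 and compound 3 the difference is 3-fluorophenyl in place of 2-fluorophenyl on a saturated chain carbon bound to an aromatic nitrogen; it gives a 19-fold higher number from compound 1 to compound 3 (1.28 log units; beyond the scatter). Between compound 1 and compound 2 the difference is fluoro in place of hydrogen on an aromatic carbon, and this gives a 12-fold higher number from compound 1 to compound 2 (1.07 log units; beyond the scatter). Compound 2 and compound 3 lie close together: a 1.6-fold higher number from compound 2 to compound 3 (0.22 log units; within the scatter).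

Compound 4, `O=C(O)CN1C(=O)/C(=C/c2nc3ccccc3n2Cc2ccc(F)c(F)c2)SC1=S`, has not yet been measured. It differs from compound 3 by fluoro in place of hydrogen on an aromatic carbon. Among the compounds with values here, this is the same kind of change as the one from compound 1 to compound 2, but not the same change: in compound 2 the entering fluoro sits meta to a fluoro group, whereas in compound 4 it sits ortho to a fluoro group; in both it is para to a large group. Two things weigh here. Within the data shown here, the one measured example of this kind of change, a 12-fold higher number from compound 1 to compound 2 (1.07 log units; beyond the scatter), was a large step upward. Yet compound 3 already shows the highest number of the three at 35700 nM, and compound 2 and compound 3 are within the scatter of each other, so a further rise of the same size is not assured. Compound 4 is therefore expected to give a step of a 1.4-fold higher number from compound 3 to compound 4 (0.15 log units; within the scatter) in this assay, smaller than the measured step of the same kind. The estimate for compound 4 is 50000 nM, with an expected range from 15000 nM to 150000 nM, and it is possible that this assay reports only a limit for compound 4.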

Compound 4, half-maximal inhibitory concentration: 5970 nM
Compound 4: the middle estimate sits 8.4-fold (0.92 log units) above what was measured, outside the stated range (below it).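

In this assay, the new change gives a 6.0-fold lower number from compound 3 to compound 4 (0.78 log units; beyond the scatter), so the same fluoro that raised the number on the core of compound 1 lowers it on the core of compound 3, and the two steps clearly differ: the same change on two cores in this assay, a 12-fold higher number (1.07 log units; beyond the scatter) from compound 1 to compound 2 and a 6.0-fold lower number (0.78 log units; beyond the scatter) from compound 3 to compound 4, 70-fold (1.84 log units) apart, beyond the scatter of two such steps.
This shows that, in this series, the effect of adding this fluoro cannot be carried from one core to another as a fixed size, or even as a fixed direction. The comparison does not show why the steps part ways, and two pairs are too few to give a rule, although the other steps place compound 4 among its relatives, with a 3.6-fold lower number from compound 2 to compound 4 (0.56 log units; beyond the scatter) and a 3.2-fold higher number from compound 1 to compound 4 (0.51 log units; beyond the scatter), as the middle of the set.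

The compounds shown leave open whether a chloro or a methoxy group entering at the same place would follow the fluoro on these two cores. They also leave open whether the reversal would appear with the same fluoro on a core carrying a chloro group instead of the first fluoro.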